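Triazole aryl substituent changes in the spiro-oxindole series

This account rests on a few compounds, and the source may have more. Where it says the series, first, only, none or still open, it means among the compounds named here.

Compound 1 `CCc1ccccc1-n1nncc1CN1C(=O)C2(C(C#N)=C(N)Oc3c(N)cc4nc5ccccc5nc4c32)c2ccccc21` gives 17900 nM in a functional assay on HepG2 cells (Homo sapiens) for antiproliferative activity, read by MTT assay, with a stated time of 48 h; on this read-out lower numbers stand for stronger inhibition and higher numbers for weaker inhibition.
Compound 2 `N#CC1=C(N)Oc2c(N)cc3nc4ccccc4nc3c2C12C(=O)N(Cc1cnnn1-c1ccc(F)cc1)c1ccccc12` reaches only the assay limit, > 50000 nM.
Compound 3 `CC(=O)Nc1ccc(-n2nncc2CN2C(=O)C3(C(C#N)=C(N)Oc4c(N)cc5nc6ccccc6nc5c43)c3ccccc32)cc1` likewise reaches only the assay limit, > 50000 nM.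

Compound 3 therefore stands at the weak end of the numbers shown, and it is not alone there: the limit of > 50000 nM in this assay, at which 2 of the 3 values shown sit. Compound 4 `Cc1ccc(-n2nncc2CN2C(=O)C3(C(C#N)=C(N)Oc4c(N)cc5nc6ccccc6nc5c43)c3ccccc32)cc1C` differs from compound 3 by 3,4-dimethylphenyl in place of 4-acetamidophenyl on an aromatic nitrogen.

Among the compounds with values here, two measured steps bear on this change. Going from 2-ethylphenyl to 4-fluorophenyl gave an at least 2.7-fold higher number from compound 1 to compound 2 (0.44 log units; beyond the scatter), and going from 2-ethylphenyl to 4-acetamidophenyl gave an at least 2.7-fold higher number from compound 1 to compound 3 (0.44 log units; beyond the scatter). The direct comparison between those two, a step that the two limits leave unreadable from compound 2 to compound 3, is not readable. Within the data shown here, only 2-ethylphenyl, in compound 1, has produced a number below the limit; 3,4-dimethylphenyl carries alkyl groups as that group does, but no measured compound shows whether alkyl groups in these positions behave like it. A modest move towards a readable number is expected, with a real chance that compound 4 again stops at the limit.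

Compound 4 is estimated at 40000 nM, between 15000 nM and 80000 nM. That estimate corresponds to an expected step of an at least 1.2-fold lower number from compound 3 to compound 4 (0.09 log units; that floor lies within the scatter).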

Compound 4, half-maximal inhibitory concentration: > 50000 nM
Compound 4: no number, only a limit; the forecaster's own chance of this, stated with the estimate: 55%; middle value at least 1.2-fold (0.09 log units) away from the limit.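

Alkyl groups on the phenyl ring do not by themselves bring a readable number in this assay: compound 4, with 3,4-dimethylphenyl, gives only a limit of the assay, > 50000 nM. Within the data shown here, on this aromatic nitrogen, 3,4-dimethylphenyl in place of 2-ethylphenyl gives an at least 2.7-fold higher number from compound 1 to compound 4 (0.44 log units; beyond the scatter), so 2-ethylphenyl remains the only group here with a number below the limit. The steps to compound 4 from compound 2 and from compound 3 cannot be read, and the values now gather at one end of the range: the limit of > 50000 nM in this assay, at which 3 of the 4 values shown sit.

Open, from the compounds shown here alone, is whether 2-methylphenyl or 4-ethylphenyl on this nitrogen would also give a number below the limit, which would separate the ethyl group from its placement. Going by these compounds, the order among 4-fluorophenyl, 4-acetamidophenyl and 3,4-dimethylphenyl also remains open.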